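This account rests on a few compounds, and the source may have more. Where it says the series, first, only, none or still open, it means among the compounds named here.

In a toxicity assay on MT4 cells (Homo sapiens) for cytotoxicity, read by MTT assay (a higher number here means that more compound is tolerated, a lower number that less compound is tolerated), three compounds have been measured so far:

- Compound 1 `O=c1ccn([C@@H]2C=C[C@@]3(CO)C[C@@H]23)c(=O)[nH]1`: > 100 ug/mL
- Compound 2 `O=c1nc(O)ccn1[C@H]1C=C[C@]2(CO)C[C@H]12`: > 100 ug/mL
- Compound 3 `Nc1ccn([C@@H]2C=C[C@@]3(CO)C[C@@H]23)c(=O)n1`: > 100 ug/mL

All three entries are limits of the assay and not numbers. The evidence is uniform: the limit of > 100 ug/mL in this assay, at which 3 of the 3 values shown sit. Compound 3 gives > 100 ug/mL, which is a limit. Its exact position on the scale is therefore unknown, and it cannot be ranked against compound 1 or compound 2.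

The next compound is compound 4 `Nc1ccn([C@H]2C=C[C@]3(CO)C[C@H]23)c(=O)n1`, which has not yet been measured. Its relation to compound 3 is purely one of configuration: the two compounds have the same atoms and bonds and differ only in configuration as drawn: 3 of 3 stereo elements differ (all stereocentres are inverted: mirror images); a stereocentre at a saturated ring carbon is drawn R in compound 3 and S in compound 4; a stereocentre at a saturated ring carbon is drawn S in compound 3 and R in compound 4; a stereocentre at a saturated ring carbon is drawn R in compound 3 and S in compound 4. For the measured compounds named here, no measured pair in this set shows what such a change does in this assay, so the expectation rests only on the three limits. No shift beyond the usual scatter is expected, in either direction. The expected change is a number no higher from compound 3 to compound 4 (the limit leaves the size open). Another report of only a limit is considered the most likely outcome. The estimated half-maximal cytotoxic concentration for compound 4 is 100 ug/mL, with an expected range from 40 ug/mL to 200 ug/mL.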

Compound 4, half-maximal cytotoxic concentration: 61.8 ug/mL
Compound 4: middle estimate off by 1.6-fold (0.21 log units), on the high side, and the stated range covers the measured number.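

In this assay, for the compounds shown here, compound 4 is the first compound to give a number and not a limit, 61.8 ug/mL, so the mirror-image change now has a measured end. Inverting all three stereocentres gives an at least 1.6-fold lower number from compound 3 to compound 4 (0.20 log units; that floor lies within the scatter), and amino in place of hydroxy on an aromatic carbon gives an at least 1.6-fold lower number from compound 2 to compound 4 (0.20 log units; that floor lies within the scatter); both floors lie within the scatter, so neither step shows a change beyond it, though neither rules one out. Any real gap in the first of these steps could come only from the drawn configuration, because nothing else separates the pair: the fact that compounds 3 and 4 differ only in the configuration as drawn

How far either step actually reaches stays open, because only one end of each is a number: the limit of > 100 ug/mL in this assay, at which 3 of the 4 values shown sit. The compounds shown also leave open how a carboxylic acid or a longer chain on the shared core would read in this assay, and whether the mirror-image change would then give a step of the same size.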